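The source may report more compounds than this note shows. Statements on the series, on what has been measured and on what is new or still open speak of the compounds shown alone.

Compound 1, `COc1ccc(CNc2nc([SeH])nc3ccccc23)cc1`: in a functional assay on CCRF-CEM cells (Homo sapiens) for cytotoxicity, read by MTT assay, with a stated time of 72 h (a lower number here means a stronger inhibitor of growth, a higher number a weaker inhibitor of growth), compound 1 reaches only a limit of the assay, > 100000 nM.
Compound 2, `CSc1nc(NCc2ccc([Se]C)cc2)c2ccccc2n1`: in this assay compound 2 reaches only a limit of the assay, > 100000 nM.
Compound 3, `CSc1nc(NCc2ccccc2)c2ccccc2n1`: in this assay compound 3 reaches only a limit of the assay, > 100000 nM.

None of these three compounds gives a number in this assay; every value shown sits at the limit of > 100000 nM in this assay, at which 3 of the 3 values shown sit, so compound 3 stands exactly where the other two stand, and nothing separates them. For the measured compounds named here, the only single-point step among the measured compounds, a step that the two limits leave unreadable from compound 2 to compound 3, runs between two limits and therefore cannot be read in size or direction.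

Compound 4, `COc1ccc(CNc2nc(SC)nc3ccccc23)cc1`, differs from compound 3 by methoxy in place of hydrogen on an aromatic carbon. Compound 1 already carries this methoxy group, alongside a different substituent on the shared core, and still sits at the limit. No measured step shows what the methoxy group does, so the expectation for compound 4 rests on the fact that every shown value is a limit. The step expected from compound 3 to compound 4 is a number no higher from compound 3 to compound 4 (the limit leaves the size open), meaning nothing that the assay is expected to resolve. Compound 4 is thus estimated to reach 100000 nM, within 30000 nM to 300000 nM, most likely as a limit once more.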

Compound 4, concentration for total growth inhibition: > 100000 nM
Compound 4: only a limit was reported; the forecaster's own chance of this, stated with the estimate: 85%; the middle value lies on the limit itself.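

Compound 4 also reaches only a limit in this assay, so its steps from compound 1, compound 2 and compound 3 cannot be read in size or direction, and all four compounds stand together: the limit of > 100000 nM in this assay, at which 4 of the 4 values shown sit. The compounds shown leave open whether the methoxy group, or any other change among them, alters growth inhibition at all.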